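The source may hold more compounds than are shown below. What is called first, only, known or untested is meant among the compounds shown, and "the series" means these compounds.

Measured so far in a functional assay on RS4-11 cells (Homo sapiens) for inhibition, read by CCK-8 assay, with a stated time of 48 h; a higher number here means a weaker inhibitor, a lower number a stronger inhibitor:
compound 1 `COc1ccc(Oc2ccccc2-c2ccsc2S(=O)(=O)N2CCN(C(=O)Nc3cccc([N+](=O)[O-])c3)CC2)cc1OC`: > 50000 nM
compound 2 `O=[N+]([O-])c1ccc(NC(=S)NCCNS(=O)(=O)c2ccc(-c3ccccc3OCc3cccc(O)c3)s2)cc1`: 10100 nM
compound 3 `O=[N+]([O-])c1cccc(NC(=S)NCCNS(=O)(=O)c2ccc(-c3ccccc3OCc3cccc(O)c3)s2)c1`: 9800 nM

In this assay compound 2 gives 10100 nM and compound 3 gives 9800 nM. For compound 1 the result is only a limit of the assay, > 50000 nM. The change from compound 3 to compound 2 is 4-nitrophenyl in place of 3-nitrophenyl on an amide-type nitrogen; it made a 1.0-fold higher number from compound 3 to compound 2 (0.01 log units; within the scatter). Compound 4 `COc1ccc(Oc2ccccc2-c2ccsc2S(=O)(=O)N2CCN(C(=O)Nc3ccc([N+](=O)[O-])cc3)CC2)cc1OC` has not yet been measured. It differs from compound 1 by 4-nitrophenyl in place of 3-nitrophenyl on an amide-type nitrogen, the same kind of change, though here the amide-type nitrogen's other neighbour is a carbonyl carbon rather than a thiocarbonyl carbon. How the core of compound 1 differs from that of compound 3 is not broken down here. Because compound 1 sits at the limit (the limit of > 50000 nM in this assay, at which 1 of the 3 values shown sits), and the kindred step lay within the scatter, the expected step is a step that the limit leaves unreadable from compound 1 to compound 4. For compound 4 the estimate in this assay is 60000 nM, expected between 20000 nM and 200000 nM, most likely again only a limit.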

Compound 4, half-maximal inhibitory concentration: > 50000 nM
Compound 4 was reported as a limit (the forecaster's own chance of this, stated with the estimate: 80%); the middle value is on the limit's open side.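

In this assay, within the data shown here, compound 1 and compound 4 are both reported only as limits of the assay, so no step between them can be read: the limit of > 50000 nM in this assay, at which 2 of the 4 values shown sit. The compounds shown leave open whether 4-nitrophenyl in place of 3-nitrophenyl changes anything on the core of compound 1.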